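Lengthening a Weak Adenosine Binder with a Hydroxyl Tail

The compounds below may be only part of what the source reports. "The series", "measured", "known", "first", "only" and "open" are said of these compounds alone.

Measured compounds:
compound 1, `CCCCCCNc1nc(-c2ccccc2)nc2c1nnn2Cc1ccccc1F` — 25000000 nM
compound 2, `CCNc1nc(-c2ccccc2)nc2c1nnn2Cc1ccccc1F` — 11000000 nM

Of the compounds shown here, two sharing one core have been tested in an assay on isolated protein for binding affinity to adenosine receptor A1 (Bos taurus); a higher number here means a weaker inhibitor, a lower number a stronger inhibitor. Compound 1 `CCCCCCNc1nc(-c2ccccc2)nc2c1nnn2Cc1ccccc1F` gives 25000000 nM in that assay. Compound 2 `CCNc1nc(-c2ccccc2)nc2c1nnn2Cc1ccccc1F` gives 11000000 nM. Compound 2 therefore stands lowest of the two numbers, and its nearest neighbour is compound 1: a 2.3-fold lower number from compound 1 to compound 2 (0.36 log units; beyond the scatter). Compound 3 `OCCCNc1nc(-c2ccccc2)nc2c1nnn2Cc1ccccc1F` has not yet been measured; it differs from compound 2 by hydroxymethyl in place of hydrogen on a saturated chain carbon, two bonds along the chain from a nitrogen on an aromatic ring. Going by the values given here, the only step that bears on this change is a 2.3-fold lower number from compound 1 to compound 2 (0.36 log units; beyond the scatter), which also altered the length of the same chain and was modest in size. Nothing shown points to a large shift from a hydroxymethyl at this place. Compound 3 is therefore expected to give about 10000000 nM in this assay, between 3000000 nM and 40000000 nM. This amounts to an expected step of a 1.1-fold lower number from compound 2 to compound 3 (0.04 log units; within the scatter), lying within the scatter.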

Compound 3, inhibition constant: 3700000 nM
Compound 3: middle estimate off by 2.7-fold (0.43 log units), on the high side; the range from low to high includes it.
By their numbers in this assay, from the lowest: compound 3; then compound 2; then compound 1.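

In this assay, replacing ethyl with 3-hydroxypropyl gave a 3.0-fold lower number from compound 2 to compound 3 (0.47 log units; beyond the scatter) and so placed compound 3 lowest of the three, while the comparison with the longest chain gave a 6.8-fold lower number from compound 1 to compound 3 (0.83 log units; beyond the scatter) on the same shared core. Compound 1 alone had suggested that a longer chain at this position goes with a higher number, but compound 3 goes against that reading, since its chain is longer than that of compound 2 and its number is lower. No measurement shown explains this step.

The compounds shown do not separate the added chain length from the hydroxyl, as a plain propyl chain is not among them. As far as these compounds go, it also remains open how an amine or a carboxylic acid at the end of this chain, or a hydroxyl on a longer chain, would compare.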